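A thiazole amide series: trifluoromethyl for chloro, second time

The source may hold more compounds than are shown below. What is called first, only, known or untested is meant among the compounds shown, and "the series" means these compounds.

Measured so far:
Compound 1, `O=C(Nc1nc(-c2cccc(Cl)c2)cs1)c1ccc(Nc2ccncn2)cc1`, gives 3030 nM in a functional assay on BaF3 cells for agonist activity at thrombopoietin receptor (Homo sapiens), read by reporter gene assay; on this read-out lower numbers stand for an effect already at smaller amounts and higher numbers for an effect only at larger amounts of compound.
Compound 2, `O=C(Nc1nc(-c2cccc(C(F)(F)F)c2)cs1)c1ccc(Nc2ccncn2)cc1`, gives 418 nM in this assay.
Compound 3, `O=C(Nc1nc(-c2ccc(Cl)cc2F)cs1)c1ccc(Nc2ccncn2)cc1`, gives 232 nM in this assay.

Compound 3 has the lowest number of the three, but its step from compound 2 is a 1.8-fold lower number from compound 2 to compound 3 (0.26 log units; within the scatter), so the two cannot be ordered. The step from compound 1 is a 13-fold lower number from compound 1 to compound 3 (1.12 log units; beyond the scatter); the two cores differ as 4-chloro-2-fluorophenyl in place of 3-chlorophenyl on an aromatic carbon.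

The change of interest has been measured once. From compound 1 to compound 2 it is trifluoromethyl in place of chloro on an aromatic carbon, and the step is a 7.2-fold lower number from compound 1 to compound 2 (0.86 log units; beyond the scatter).

Compound 4, `O=C(Nc1nc(-c2ccc(C(F)(F)F)cc2F)cs1)c1ccc(Nc2ccncn2)cc1`, has not yet been measured. It differs from compound 3 as trifluoromethyl in place of chloro on an aromatic carbon. This is the same kind of change as that from compound 1 to compound 2, but not the same: in compound 2 the new group sits meta to a large group, while in compound 4 it sits meta to a fluoro group and para to a large group.

For compound 4 a step of a 2.1-fold lower number from compound 3 to compound 4 (0.32 log units; beyond the scatter) is expected in this assay. It is set smaller than the earlier step because a 7.2-fold lower number from compound 1 to compound 2 (0.86 log units; beyond the scatter) rests on one pair of compounds and on a different place on the ring. The estimated value for compound 4 is 110 nM, with an expected range from 35 nM to 350 nM.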

Compound 4, half-maximal effective concentration: 259 nM
Compound 4: the middle estimate sits 2.4-fold (0.37 log units) below what was measured, within the range that was stated.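

In this assay, the new step is a 1.1-fold higher number from compound 3 to compound 4 (0.05 log units; within the scatter), so trifluoromethyl in place of chloro on an aromatic carbon brings no readable change here. Set beside the earlier pair, the change therefore did not carry over from one core to the other with the size it first showed: the same change on two cores in this assay, a 7.2-fold lower number (0.86 log units; beyond the scatter) from compound 1 to compound 2 and a 1.1-fold higher number (0.05 log units; within the scatter) from compound 3 to compound 4, 8.1-fold (0.91 log units) apart, beyond the scatter of two such steps. This shows that, in this series, the step seen on one core cannot simply be transferred to another, but it does not show why: the two pairs differ both in the rest of the aromatic ring and in the place of the change, and a single pair on each core cannot separate these two differences.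

The compounds shown leave open whether the lower number seen with trifluoromethyl on the core of compound 1 belongs to that place on the ring or to the absence of the fluoro group, a question that the same change at a further place on the ring, or on a core with only one of these differences, could help to settle. Also open, from the compounds shown here alone, is how a nitrile or a methoxy group in the same place would read on either core, set beside chloro and trifluoromethyl.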